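The source may hold more compounds than are shown below. What is called first, only, known or untested is meant among the compounds shown, and "the series" means these compounds.

The measured compounds:
Compound 1 `CCCN(CCC)CCNc1nnc(-c2ccccc2)cc1C`; in a functional assay on the whole organism for positive allosteric modulation, with Mus musculus as the target (on this read-out higher numbers stand for an effect only at larger amounts of compound and lower numbers for an effect already at smaller amounts), compound 1 gives > 30 mg/kg, which is a limit of the assay and not a number.
Compound 2 `CCN(CC)CCNc1nnc(-c2ccccc2)cc1C`; in this assay compound 2 gives > 30 mg/kg, again only a limit.
Compound 3 `Cc1cc(-c2ccccc2)nnc1NCCN(C)C`; in this assay compound 3 gives > 30 mg/kg, also a limit.

Compound 2 thus stands at the same limit as the other two, (the limit of > 30 mg/kg in this assay, at which 3 of the 3 values shown sit). The steps among the measured compounds, a step that the two limits leave unreadable from compound 1 to compound 2, a step that the two limits leave unreadable from compound 1 to compound 3 and a step that the two limits leave unreadable from compound 2 to compound 3, cannot be read in size, since each rests on two limits rather than on numbers. Compound 4 `Cc1cc(-c2ccccc2)nnc1NC(C)CN` has not yet been tested. It differs from compound 2 by 1-(aminomethyl)ethyl in place of 2-(diethylamino)ethyl on a nitrogen on an aromatic ring. Within the data shown here, none of the measured steps covers this change, and none has a readable size, so there is no measured basis for a step in this assay in either direction, nor for one beyond the scatter. The step from compound 2 to compound 4 is therefore estimated as a number no higher from compound 2 to compound 4 (the limit leaves the size open), with a further limit the most likely outcome. Compound 4 is expected to give 30 mg/kg, within a range from 10 mg/kg to 100 mg/kg.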

Compound 4, dose for half-maximal effect: > 30 mg/kg
Compound 4: no number, only a limit (the forecaster's own chance of this, stated with the estimate: 70%); the middle value sits exactly at the limit.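

Compound 4, like compound 2 and compound 3, gives only a limit and not a number, so the steps from compound 2 and compound 3 to compound 4 cannot be read in size: the limit of > 30 mg/kg in this assay, at which 4 of the 4 values shown sit.

The compounds shown leave open how these groups on the nitrogen truly compare in effect.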